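A Chloro-to-Cyano Swap on a Compound at the Limit

The compounds below may be only part of what the source reports. "The series", "measured", "known", "first", "only" and "open" are said of these compounds alone.

In a functional assay on Huh-7 cells (Homo sapiens) for antiproliferative activity, with a stated time of 48 h (a lower number here means a stronger inhibitor, a higher number a weaker inhibitor), compound 1 (`CC(=O)c1ccc(-c2ccc(N3CCCC3)nn2)cc1`) gives 30000 nM and compound 2 (`COc1ccc(Nc2ccc(-c3ccccc3)nn2)cc1`) gives 30000 nM as well, so these two results cannot be told apart. Compound 3 (`CCN(CC)c1ccc(-c2cccc(Cl)c2)nn1`) carries no number, only a limit: > 25000 nM is what the assay reports for it. So compound 3 stands at the limit of > 25000 nM in this assay, at which 1 of the 3 values shown sits, and has no exact place among the others.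

Compound 4 (`CCN(CC)c1ccc(-c2cccc(C#N)c2)nn1`) keeps the rest of compound 3 and has cyano in place of chloro on an aromatic carbon, meta to a large group: cyano in place of chloro on an aromatic carbon is the full count of this change.

Within the data shown here, no pair of tested compounds differs in just one place, so the data offer no direct measure of how large such a step tends to be. Among the measured compounds shown here, with compound 1 at 30000 nM and compound 2 at 30000 nM as the only numbers to go on, the expectation is no step beyond the scatter, in either direction. In figures, the expected change is a step that the limit leaves unreadable from compound 3 to compound 4 as an estimate. Compound 4 is estimated at 28000 nM with an expected range of 12000 nM to 50000 nM once measured.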

Compound 4, half-maximal inhibitory concentration: > 25000 nM
Compound 4: no number, only a limit (the forecaster's own chance of this, stated with the estimate: 55%); the middle value is on the limit's open side.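

Neither compound 3 nor compound 4 has an exact number, so the swap of chloro for cyano gives no step that can be read, because both stand at the same limit: the limit of > 25000 nM in this assay, at which 2 of the 4 values shown sit.

The compounds shown leave open whether this swap changes antiproliferative activity at all, and how far past that limit each compound lies.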